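Swapping a thioether aryl group on a diamino core

The source may report more compounds than this note shows. Statements on the series, on what has been measured and on what is new or still open speak of the compounds shown alone.

Compound 3 `COc1ccc(Sc2nc3cc(N)cc(N)c3nc2-c2ccccc2)cc1` carries a (4-methoxyphenyl)sulfanyl group on the shared core. In a functional assay on NCI-H522 cells (Homo sapiens) for inhibition, read by sulforhodamine B assay, with a stated time of 48 h (a lower number here means that less compound is tolerated, a higher number that more compound is tolerated), compound 3 gives only a limit of the assay, < 100000 nM, not a number. Compound 1 `Nc1cc(N)c2nc(-c3ccccc3)c(Oc3ccc(Cl)c(Cl)c3)nc2c1` bears a 3,4-dichlorophenoxy group in the same place. In this assay compound 1 also gives a limit, < 100000 nM. Compound 2 `Nc1cc(N)c2nc(-c3ccccc3)c(NCc3ccc(F)cc3)nc2c1` has a (4-fluorobenzyl)amino group there. In this assay compound 2 likewise gives a limit, < 100000 nM. Because of the limit of < 100000 nM in this assay, at which 3 of the 3 values shown sit, none of the three steps can be sized: the step that the two limits leave unreadable from compound 1 to compound 2, the step that the two limits leave unreadable from compound 1 to compound 3 and the step that the two limits leave unreadable from compound 2 to compound 3 all lie between two limits.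

Compound 4 `Nc1cc(N)c2nc(-c3ccccc3)c(Sc3ccc(Cl)c(Cl)c3)nc2c1` is the thioether partner of compound 1: the change is 3,4-dichlorophenyl in place of 4-methoxyphenyl on a sulfur. No measured step is readable, so nothing on the numbers shown says whether this change moves this assay up or down. All that the three limits suggest is that compound 4 is also expected to sit at or under the same limit, so the step that the limit leaves unreadable from compound 3 to compound 4 is expected to be unreadable in the same way. For compound 4 the estimate in this assay is 20000 nM, expected to fall between 3000 nM and 90000 nM.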

Compound 4, concentration lethal to 50% of the cells: < 100000 nM
Compound 4 ended at the assay's limit; the forecaster's own chance of this, stated with the estimate: 80%; the middle value does not contradict the limit.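

No step from compound 1, compound 2 or compound 3 to compound 4 can be read, because all of these compounds give a limit and not a number: the limit of < 100000 nM in this assay, at which 4 of the 4 values shown sit. The compounds shown leave open whether exchanging these groups on the shared core moves this assay at all, and if so, in which direction and how far.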